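Series notes: bromo for fluoro, compound 3 to compound 4

The source may report more compounds than this note shows. Statements on the series, on what has been measured and on what is new or still open speak of the compounds shown alone.

Compound 1 `O=C(CSc1nc(Nc2ccccc2)c2ccccc2n1)Nc1ccccc1F`; in a functional assay on MDA-MB-231 cells (Homo sapiens) for inhibition, read by MTT assay, with a stated time of 72 h (on this read-out lower numbers stand for stronger inhibition and higher numbers for weaker inhibition), compound 1 reaches only the assay limit, > 50000 nM.
Compound 2 `O=C(CSc1nc(Nc2ccccc2)c2ccccc2n1)Nc1ccc(F)cc1`; in this assay compound 2 gives 34100 nM.
Compound 3 `C=CC(=O)Nc1cccc(NC(=O)CSc2nc(Nc3ccccc3F)c3ccccc3n2)c1`; in this assay compound 3 gives 18700 nM.

Compound 3 holds the lowest of the two numbers in hand, but its nearest neighbour, compound 2, sits within the usual scatter of it, so no order between them can be claimed. Compound 1 contributes a limit only, (the limit of > 50000 nM in this assay, at which 1 of the 3 values shown sits). Within the data shown here, the one measured step, an at least 1.4-fold lower number from compound 1 to compound 2 (0.16 log units; that floor lies within the scatter), moves a fluoro between positions on the amide-side ring; its floor lies within the scatter and it touches a different ring from the change now considered.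

Compound 4 `C=CC(=O)Nc1cccc(NC(=O)CSc2nc(Nc3ccccc3Br)c3ccccc3n2)c1` differs from compound 3 by bromo in place of fluoro on an aromatic carbon. Among the measured compounds shown here, no measured step addresses a halogen swap on this ring, so the step from compound 1 to compound 2 bears on it only as a sign that single halogen edits have so far stayed small. The expected step of a 1.2-fold lower number from compound 3 to compound 4 (0.10 log units; within the scatter) is therefore none beyond the scatter. Compound 4 is estimated at 15000 nM, within 5000 nM to 45000 nM.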

Compound 4, half-maximal inhibitory concentration: 15200 nM
Compound 4: middle estimate off by 1.0-fold (0.01 log units), on the low side; the range from low to high includes it.
By their numbers in this assay, from the lowest: compounds 4, 3 and 2 (each within the scatter of the next, the first and the last beyond it). At a limit, above all of these: compound 1.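

Going from (2-fluorophenyl)amino to (2-bromophenyl)amino gives a 1.2-fold lower number from compound 3 to compound 4 (0.09 log units; within the scatter) in this assay, the first measured edit at this position, as the earlier step touched only the amide-side ring. On this read-out the two halogens cannot be told apart here, so this single swap gives no handle on the number, and compound 4 sits with compound 3 in the same band. Nothing in hand bears on a cause for this step.

Left open is whether a non-halogen group on this ring, such as methoxy or an amine, would move the number beyond the scatter. Also open, as far as these compounds go, is what a saturated propanamide in place of the acrylamide would do to compound 3 or compound 4 in this assay.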